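The source may report more compounds than this note shows. Statements on the series, on what has been measured and on what is new or still open speak of the compounds shown alone.

Compound 1 `Cc1c(OC[C@@H](C)COc2ccc(Cl)c(C(=O)O)c2)ccc(C(=O)CC(C)(C)C)c1O` — 377 nM
Compound 2 `Cc1c(OC[C@@H](C)COc2ccc3c(c2)C(=O)NC3)ccc(C(=O)CC(C)(C)C)c1O` — > 10000 nM

In an assay for positive allosteric modulation of metabotropic glutamate receptor 2 (Rattus norvegicus) (a lower number here means that less compound is needed, a higher number that more compound is needed for the effect), compound 1 gives 377 nM. Compound 2 gives > 10000 nM, which is a limit of the assay and not a number. Among the compounds with values here, the only measured step, an at least 26-fold higher number from compound 1 to compound 2 (1.42 log units; beyond the scatter), therefore ends at the limit of > 10000 nM in this assay, at which 1 of the 2 values shown sits, so the true distance between the two compounds is not known, only that it is large.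

Compound 3, `COc1cccc(OC[C@H](C)COc2ccc(C(=O)CC(C)(C)C)c(O)c2C)c1`, has not yet been measured. It differs from compound 2 in a group of 8 heavy atoms (7 carbon, 1 oxygen; one six-membered aromatic ring of carbon only) in place of a group of 10 heavy atoms (8 carbon, 1 nitrogen, 1 oxygen; one five-membered non-aromatic ring with 1 hetero atom, one six-membered aromatic ring of carbon only), on an oxygen on a saturated carbon. The step from compound 1 to compound 2 is the only one that bears on this change: it shows that exchanging the group on this oxygen can shift the read-out of this assay a long way, but it does not tell where a 3-methoxyphenyl stands relative to either of the two measured groups. An intermediate outcome is expected, with a real chance that compound 3 also returns only a limit. Compound 3 is estimated at 3000 nM in this assay, within a range of 500 nM to 20000 nM, which would correspond to an expected step of an at least 3.3-fold lower number from compound 2 to compound 3 (0.52 log units; beyond the scatter).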

Compound 3, half-maximal effective concentration: "not active" (no number reported)
Nothing numeric was reported for compound 3; no gap can be computed for the estimate.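

No new step can be read: in this assay compound 3 is reported only as "not active", with no number. Compound 2 gives > 10000 nM, which is a limit and not a number. The compounds shown leave open how far either compound 2 or compound 3, with its 3-methoxyphenyl, truly lies from compound 1.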